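Fluoro replacement for the aminomethyl arm in the series

The source may hold more compounds than are shown below. What is called first, only, known or untested is meant among the compounds shown, and "the series" means these compounds.

Two analogues sharing one core have been measured so far. Compound 1 `CCc1nnc(-c2ccc(-c3ccccc3)cc2)n1-c1cccc(CO)c1C` carries a hydroxymethyl group and in an assay on C6 glioma cells for displacement of a labelled ligand from sodium- and chloride-dependent glycine transporter 1 (Rattus norvegicus), read by scintillation counting, with stated times of 30 min and 10 min (on this read-out higher numbers stand for weaker inhibition and lower numbers for stronger inhibition), compound 1 gives 250 nM. Compound 2 `CCc1nnc(-c2ccc(-c3ccccc3)cc2)n1-c1cccc(CN(C)C)c1C` carries a (dimethylamino)methyl group in its place and in this assay compound 2 gives 29000 nM. For the measured compounds named here, the one measured step, a 120-fold higher number from compound 1 to compound 2 (2.06 log units; beyond the scatter), is the only comparison available. On the numbers shown compound 2 stands at the weak end: its value is the higher of the two, and the gap to compound 1 lies beyond the scatter.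

Compound 3 `CCc1nnc(-c2ccc(-c3ccccc3)cc2)n1-c1cccc(F)c1C` has not yet been measured. It differs from compound 2 by fluoro in place of (dimethylamino)methyl on an aromatic carbon. Going by the values given here, no measured step covers this exact exchange. Among the compounds with values here, what bears on it is only the step from compound 1 to compound 2, which showed that the (dimethylamino)methyl group sits with the weaker number; removing it in compound 3 for a single fluorine is therefore expected to move the number back down, toward the range of compound 1, though whether the fluoro analogue reaches compound 1 is unknown. The expected step is a 58-fold lower number from compound 2 to compound 3 (1.76 log units; beyond the scatter). For compound 3 in this assay the estimate is 500 nM, with a range of 80 nM to 3000 nM.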

Compound 3, half-maximal inhibitory concentration: 630 nM
Compound 3: middle estimate off by 1.3-fold (0.10 log units), on the low side; the range from low to high includes it.
By their numbers in this assay, from the lowest: compound 1; then compound 3; then compound 2.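

Notes on the arm position: in this assay, fluoro in place of (dimethylamino)methyl gives a 46-fold lower number from compound 2 to compound 3 (1.66 log units; beyond the scatter), so the weak number of compound 2 does not belong to the shared core alone and goes with the (dimethylamino)methyl group at this position, since a single fluorine on the same aromatic carbon, ortho to the methyl group, carries a much lower number. The position also separates the two groups that sit with the lower numbers: fluoro in place of hydroxymethyl gives a 2.5-fold higher number from compound 1 to compound 3 (0.40 log units; beyond the scatter), a modest step but one beyond the scatter, so a hydroxymethyl arm is not needed for a number in this range, though compound 1 remains the lowest of the three. Nothing available explains either step, and the size of each is recorded here without a cause.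

From the compounds shown here alone, whether the weak number follows the amine nitrogen or the bulk of the arm stays open, and a primary aminomethyl group, a methoxymethyl group or an ethyl group at this position would help separate the two. Going by these compounds, how far the fluoro result extends to chloro, nitrile or a carboxylic acid on the same carbon also remains open.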